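The source may report more compounds than this note shows. Statements on the series, on what has been measured and on what is new or still open speak of the compounds shown alone.

Values in a functional assay on cells for positive allosteric modulation of metabotropic glutamate receptor 2 (Homo sapiens), read by fluorescence and calcium flux, with a stated time of 30 min (on this read-out lower numbers stand for an effect already at smaller amounts and higher numbers for an effect only at larger amounts of compound), for the three measured compounds:

compound 1 `Brc1ccc(Cn2nnc3c(Br)cccc32)cc1`: 14 nM
compound 2 `Brc1cc(Br)c2nnn(CC3CC3)c2c1`: 50 nM
compound 3 `Clc1cc(Br)c2nnn(CC3CC3)c2c1`: 60 nM

Compound 3 holds the highest number of the three. Its nearest neighbour is compound 2, and the step of a 1.2-fold higher number from compound 2 to compound 3 (0.08 log units; within the scatter) lies within the scatter, so the two are not separated. Compound 1 is the furthest away; its number is lower than that of compound 3 by a margin beyond the scatter, but the two differ in more than one place, so no single change accounts for it.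

The next compound in the series is compound 4 `COc1cc(Br)c2nnn(CC3CC3)c2c1`. Relative to compound 3 the change is methoxy in place of chloro on an aromatic carbon.

Going by the values given here, only one measured step touches this position: the exchange of one halogen for another, a 1.2-fold higher number from compound 2 to compound 3 (0.08 log units; within the scatter), which stayed within the scatter. Among the compounds with values here, no measured pair exchanges a halogen for a methoxy group, so the bearing of that step on the present change is indirect. On this basis the expected outcome in this assay for compound 4 is a step of no more than modest size, most likely within the scatter and, if anything, toward a higher number, a 1.3-fold higher number from compound 3 to compound 4 (0.12 log units; within the scatter). The estimate for compound 4 is 80 nM, with a range from 25 nM to 250 nM.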

Compound 4, half-maximal effective concentration: 730 nM
Estimate against measurement, compound 4: 9.1-fold (0.96 log units) below; measured number outside the range, above it.
By their numbers in this assay, from the lowest: compound 1; then compounds 2 and 3 (each within the scatter of the next); then compound 4.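

In this assay, the position on the aromatic carbon para to a fused ring proves sensitive to what stands on it: the exchange of one halogen for another gave a 1.2-fold higher number from compound 2 to compound 3 (0.08 log units; within the scatter), whereas methoxy gave a 12-fold higher number from compound 3 to compound 4 (1.09 log units; beyond the scatter) and a 15-fold higher number from compound 2 to compound 4 (1.16 log units; beyond the scatter). The near-identity of the chloro and bromo compounds therefore does not extend to methoxy, which brings two heavy atoms and one hydrogen-bond acceptor where each halogen has one heavy atom and no acceptor. Nothing available identifies which of these differences, if either, accounts for the large steps.

The compounds shown leave open whether the higher number follows the oxygen atom, the added heavy atom or something else, and a methyl group, a hydroxyl group or an amine at this carbon would help to separate these readings. They also leave open whether the same exchange would give a step of similar size with a substituent other than the cyclopropylmethyl chain on the shared core, or with a group other than bromo on the same ring.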